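Three Inactive Amides and a Fourth Built From Them

The compounds below may be only part of what the source reports. "The series", "measured", "known", "first", "only" and "open" are said of these compounds alone.

Compound 1 `CCCCCCCCCCCCNC(=O)[C@@H](NC(=O)/C=C/c1ccccc1)[C@@H](C)O` is an amide carrying a threonine-like centre, a long saturated chain and a cinnamoyl-type arm. In a functional assay on SW-620 cells (Homo sapiens) for cytotoxicity, read by MTT assay, with a stated time of 48 h (a lower number here means a stronger inhibitor, a higher number a weaker inhibitor), compound 1 gives 200000 nM. Compound 2 `C/C=C/C=C/C(=O)N[C@H](C(=O)NCCCCCCCCCCCC)[C@@H](C)O` differs from compound 1 only by prop-1-en-1-yl in place of phenyl on a double-bonded chain carbon bound to a double-bonded chain carbon, and in this assay compound 2 gives 200000 nM; the step reads no change at the digits printed from compound 1 to compound 2 (within the scatter). Compound 3 `CCCCCCCCCCCCCCCCCCNC(=O)[C@@H](NC(=O)/C=C/c1ccccc1)[C@@H](C)O` keeps the arm of compound 1 but its core differs by hexyl in place of hydrogen on a saturated chain carbon, ten or more bonds along the chain from an amide-type nitrogen; in this assay compound 3 gives 200000 nM, and the step reads no change at the digits printed from compound 1 to compound 3 (within the scatter).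

Compound 4 `C/C=C/C=C/C(=O)N[C@H](C(=O)NCCCCCCCCCCCCCCCCCC)[C@@H](C)O` has not been measured. It differs from compound 3 by prop-1-en-1-yl in place of phenyl on a double-bonded chain carbon bound to a double-bonded chain carbon. This is the same change already made from compound 1 to compound 2, on the same kind of place, and that earlier change left the reading unmoved. Because that step was no change at the digits printed from compound 1 to compound 2 (within the scatter) and the longer chain of compound 3 also left the reading unmoved, the step from compound 3 to compound 4 is expected to be no change at the digits printed from compound 3 to compound 4 (within the scatter). Compound 4 is therefore expected to give about 200000 nM in this assay, most likely between 100000 nM and 400000 nM.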

Compound 4, half-maximal inhibitory concentration: 200000 nM
The estimate for compound 4 equals the measured number at the digits printed; the range from low to high includes it.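

In this assay, the swap of phenyl for prop-1-en-1-yl reads no change at the digits printed from compound 3 to compound 4 (within the scatter), so this change carries over from the core of compound 1 to the core of compound 3 without any visible difference: the same change on two cores in this assay, no change at the digits printed (within the scatter) from compound 1 to compound 2 and no change at the digits printed (within the scatter) from compound 3 to compound 4, 1.0-fold (0.00 log units) apart, within the scatter of two such steps

Hexyl in place of hydrogen on the saturated chain reads no change at the digits printed from compound 2 to compound 4 (within the scatter), and this second change carries over between its two cores in the same way: the same change on two cores in this assay, no change at the digits printed (within the scatter) from compound 1 to compound 3 and no change at the digits printed (within the scatter) from compound 2 to compound 4, 1.0-fold (0.00 log units) apart, within the scatter of two such steps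

Going by these compounds alone, all four compounds print the same value, so these pairs show only that both changes behave alike where the reading stays level, and they do not show how either change would carry over on a core whose reading does move.

The compounds shown leave open whether a different group in place of phenyl, such as an amine or a carboxylic acid, would shift the reading in this series. They also leave open whether a shorter chain would read differently from the saturated chains of compound 1 and compound 3.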